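Shortening the Aryl Chain of Compound 1

The compounds below may be only part of what the source reports. "The series", "measured", "known", "first", "only" and "open" are said of these compounds alone.

For the measured compounds named here, compound 1 `CCCCCc1ccc(-c2cn(C[C@H](O)[C@H]3OC(=O)C(OCc4ccccc4)=C3OCc3ccccc3)nn2)cc1` holds the lower of the two numbers measured so far: in a functional assay on MCF7 cells (Homo sapiens) for antiproliferative activity, read by MTT assay, with a stated time of 72 h (on this read-out lower numbers stand for stronger inhibition and higher numbers for weaker inhibition), compound 1 gives 9010 nM. Compound 2 `COc1ccc(-c2cn(C/C=C3\OC(=O)C(OCc4ccccc4)=C3OCc3ccccc3)nn2)cc1`, built differently at several places, gives 39100 nM, a gap beyond the usual scatter. Compound 3 `Cc1ccc(-c2cn(C[C@H](O)[C@H]3OC(=O)C(OCc4ccccc4)=C3OCc3ccccc3)nn2)cc1` differs from compound 1 by hydrogen in place of butyl on a saturated chain carbon bound to an aromatic carbon. Going by the values given here, no measured pair shows this kind of change, so no step size can be read from the data. Compound 3 is expected to be somewhat weaker, with the step of a 1.7-fold higher number from compound 1 to compound 3 (0.22 log units; within the scatter), and an estimated value of 15000 nM, within 5000 nM to 45000 nM.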

Compound 3, half-maximal inhibitory concentration: > 100000 nM
Compound 3 gave a limit, no number; the forecaster's own chance of this, stated with the estimate: 10%; middle value at least 6.6-fold (0.82 log units) from the limit.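

Cutting 4-pentylphenyl back to 4-methylphenyl is no minor trim: in this assay it brings an at least 11-fold higher number from compound 1 to compound 3 (1.04 log units; beyond the scatter). For the compounds shown here, the butyl part of the chain, on a saturated chain carbon bound to an aromatic carbon, therefore counts heavily for activity in this pair, something the earlier compounds could not show. For compound 3 the reading is a limit and not a number: the limit of > 100000 nM in this assay, at which 1 of the 3 values shown sits.

On these data alone, how activity changes between methyl and pentyl remains open. So does the effect of a longer chain such as octyl, or of an amine at the chain end.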